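Cell toxicity: from compound 3 to a long-chain relative

A few compounds are considered here, and "the series" means these few. Any claim that something is new, unique, unknown or untested is made for them only; others in the source may bear on it.

Within the data shown here, in an ADME assay on THP-1 cells (Homo sapiens) for cytotoxicity, read by MTT assay, with a stated time of 72 h (a lower number here means a stronger inhibitor, a higher number a weaker inhibitor), only one compound in this small set has a number so far: compound 1 `COc1ccc(/C=C/C(=O)NNC(=O)c2ccncc2)cc1` gives a reading (168000 nM). The entry for compound 2 `O=C(/C=C/c1ccc(OC(F)(F)F)cc1)NNC(=O)c1ccncc1` reads ("not determined" (no result reported)). The entry for compound 3 `O=C(/C=C/c1ccc(OC(F)(F)F)cc1)N/N=c1/[nH]ncc2ccccc12` reads the same way ("not determined" (no result reported)), so compound 3 has no position on the scale and offers no number to start from.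

Compound 4 `CC(C)=CCC/C(C)=C/COc1ccc(/C=C/C(=O)N/N=c2/[nH]ncc3ccccc23)cc1` differs from compound 3 in one place, on an oxygen on an aromatic ring, where trifluoromethoxy becomes (3,7-dimethylocta-2,6-dien-1-yl)oxy (3,7-dimethylocta-2,6-dien-1-yl in place of trifluoromethyl on an oxygen on an aromatic ring). Among the measured compounds shown here, no measured step exists to serve as a guide, so any forecast in this assay is a judgement with wide margins. For the measured compounds named here, the only anchor is compound 1 (168000 nM), and compound 4 is expected to land on the stronger side of that reading, by a step beyond the usual scatter. The estimate for compound 4 is 30000 nM with an expected range from 6000 nM to 130000 nM in this test.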

Compound 4, half-maximal inhibitory concentration: 56000 nM
Estimate against measurement, compound 4: 1.9-fold (0.27 log units) below; measured number inside the range.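

Compound 4 now has a reading, but compound 3 has none to set against it, so no step can be read between them. From the compounds shown here alone, what replacing trifluoromethyl with 3,7-dimethylocta-2,6-dien-1-yl does to cell toxicity stays open. No supporting evidence bears on this result.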